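A halogen swap on the ester and its expected effect

The source may hold more compounds than are shown below. What is called first, only, known or untested is meant among the compounds shown, and "the series" means these compounds.

Measured in an assay on isolated protein for inhibition of matrix metalloproteinase-9 (Homo sapiens); a lower number here means a stronger inhibitor, a higher number a weaker inhibitor:
- compound 1, `O=C(OCc1ccccc1Br)c1cccc(=O)[nH]1`: 59000 nM
- compound 2, `CC(C)OC(=O)c1cccc(S)n1`: 132000 nM
- compound 3, `O=C(OCc1ccccc1Br)c1cccc(S)n1`: see below

Among the two numbers in hand, compound 1 has the lowest, and its nearest neighbour, compound 2, sits above it by a margin beyond the usual scatter. Compound 3 gives > 150000 nM, which is a limit of the assay and not a number; it is the limit of > 150000 nM in this assay, at which 1 of the 3 values shown sits.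

The step under study leads from compound 1 to compound 4, `O=C(OCc1ccccc1Cl)c1cccc(=O)[nH]1`, not yet measured in this assay. The two differ in one place: chloro in place of bromo on an aromatic carbon. Within the data shown here, no measured pair in the set shares this kind of change, so the size of the step has to be guessed from the change itself. Exchanging one halogen for another of the same count at the same place is a small alteration, and the step from compound 1 to compound 4 is expected to stay within the scatter, with no clear direction. Compound 4 is therefore expected to give about 70000 nM, in the range 30000 nM to 150000 nM, and the expected step from compound 1 is a 1.2-fold higher number from compound 1 to compound 4 (0.07 log units; within the scatter).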

Compound 4, half-maximal inhibitory concentration: 81000 nM
Compound 4: middle estimate off by 1.2-fold (0.06 log units), on the low side; low and high end bracket the measured number.
By their numbers in this assay, from the lowest: compounds 1, 4 and 2 (each within the scatter of the next, the first and the last beyond it). At a limit, above all of these: compound 3.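

In this assay, chloro in place of bromo on an aromatic carbon, ortho to a large group, gives a 1.4-fold higher number from compound 1 to compound 4 (0.14 log units; within the scatter), so bromo and chloro at this place cannot be told apart by this read-out. Among these compounds, until compound 4, no pair in the set differed at this halogen, and nothing showed how this place answers to a change of one halogen for another; this pair now gives a first reading, a single exchange on a single ester, and that reading shows no clear direction. No measurement shown gives a reason for the size of this step, and none speaks to any property of the two halogens.

From the compounds shown here alone, what remains open is whether this place answers at all to a group other than a halogen, such as a methoxy group, an amine or a carboxylic acid, or to plain hydrogen in place of the halogen. Also open, going by these compounds, is whether fluoro or iodo at the same place would stay as close to compound 1 as chloro does in compound 4, or would move the number beyond the scatter.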